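Side-Chain Amide Swap at Level Antiproliferative Values

The source may report more compounds than this note shows. Statements on the series, on what has been measured and on what is new or still open speak of the compounds shown alone.

Compound 3 (`CC(=O)NCC[C@@H]1C[C@@H](c2ccc(F)c(F)c2)[C@H](NC(=O)c2cc(-c3c(Cl)cnn3C)c(Cl)o2)CN1`) reads 920 nM in a functional assay on HCT-116 cells (Homo sapiens) for antiproliferative activity, read by sulforhodamine B assay, with a stated time of 72 h (on this read-out higher numbers stand for weaker inhibition and lower numbers for stronger inhibition), and stands level with compound 1 (`Cn1ncc(Cl)c1-c1cc(C(=O)N[C@@H]2CN[C@H](CCNS(C)(=O)=O)C[C@H]2c2ccc(F)c(F)c2)oc1Cl`) at 920 nM in that read-out, while compound 2 (`Cn1ncc(Cl)c1-c1cc(C(=O)N[C@@H]2CN[C@H](CC(O)CO)C[C@H]2c2ccc(F)c(F)c2)oc1Cl`) gives 800 nM and lies within the scatter of both. Compound 4 (`CNC(=O)C[C@@H]1C[C@@H](c2ccc(F)c(F)c2)[C@H](NC(=O)c2cc(-c3c(Cl)cnn3C)c(Cl)o2)CN1`) has methylcarbamoyl in place of acetamidomethyl on a saturated chain carbon bound to a saturated ring carbon. Earlier changes at this place gave a 1.2-fold higher number from compound 2 to compound 3 (0.06 log units; within the scatter) and a 1.2-fold lower number from compound 1 to compound 2 (0.06 log units; within the scatter) while acetyl in place of methylsulfonyl on an amine nitrogen gave no change at the digits printed from compound 1 to compound 3 (within the scatter) as well. No step beyond the scatter is therefore expected, and the estimated step is a 1.0-fold lower number from compound 3 to compound 4 (0.01 log units; within the scatter) in this assay terms. Compound 4 is estimated at 900 nM (expected range 400 nM to 2000 nM).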

Compound 4, half-maximal inhibitory concentration: 1100 nM
Compound 4: middle estimate off by 1.2-fold (0.09 log units), on the low side; the range from low to high includes it.
By their numbers in this assay, from the lowest: compounds 2, 1, 3 and 4 (each within the scatter of the next).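

In this assay, methylcarbamoyl on this saturated chain carbon stays within the scatter of all three earlier side chains (a 1.2-fold higher number from compound 3 to compound 4 (0.08 log units; within the scatter)) (a 1.4-fold higher number from compound 2 to compound 4 (0.14 log units; within the scatter)) (a 1.2-fold higher number from compound 1 to compound 4 (0.08 log units; within the scatter)). The position has thus taken a group of 4 heavy atoms in place of acetamidomethyl with its 5, and no step beyond the scatter has appeared at this place in the compounds shown. As far as these compounds go, whether an amine, a carboxylic acid or a longer chain here would give such a step remains open. Nothing at hand accounts for these level values.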